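Trifluoromethyl in place of fluoro on the shared core

The source may report more compounds than this note shows. Statements on the series, on what has been measured and on what is new or still open speak of the compounds shown alone.

Measured compounds in a functional assay on A549 cells (Homo sapiens) for cytotoxicity, read by XTT assay, with a stated time of 24 h; on this read-out lower numbers stand for stronger inhibition and higher numbers for weaker inhibition:
compound 1 `Cn1nnnc1SCC(=O)N/N=C/c1ccc(F)cc1` gives 3160000 nM.
compound 2 `Cn1nnnc1SCC(=O)N/N=C/c1ccc(Br)cc1` gives > 10000000 nM, which is a limit of this assay and not a number.
compound 3 `CN(C)c1ccc(/C=N/NC(=O)CSc2nnnn2C)cc1` gives 100000 nM.

Among the two numbers, compound 1 stands highest; its nearest neighbour, compound 3, gives a 32-fold lower number from compound 1 to compound 3 (1.50 log units; beyond the scatter). Compound 4 `Cn1nnnc1SCC(=O)N/N=C/c1ccc(C(F)(F)F)cc1` differs from compound 1 by trifluoromethyl in place of fluoro on an aromatic carbon. Two measured steps from compound 1 bear on this change, and they point in opposite directions: an at least 3.1-fold higher number from compound 1 to compound 2 (0.50 log units; beyond the scatter) and a 32-fold lower number from compound 1 to compound 3 (1.50 log units; beyond the scatter). Neither swaps in a trifluoromethyl, so the size is uncertain. Compound 4 is expected to sit in this assay at 5000000 nM (range 1500000 nM to 15000000 nM), a step of a 1.6-fold higher number from compound 1 to compound 4 (0.20 log units; within the scatter), within or slightly beyond the scatter.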

Compound 4, half-maximal inhibitory concentration: 6320000 nM
Beside the measured number, compound 4's estimate is 1.3-fold (0.10 log units) below it, and the stated range covers the measured number.
By their numbers in this assay, from the lowest: compound 3; then compounds 1 and 4 (each within the scatter of the next). At a limit, above all of these: compound 2.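

In this assay, trifluoromethyl in place of fluoro on this aromatic carbon, para to a large group, gives a 2.0-fold higher number from compound 1 to compound 4 (0.30 log units; within the scatter). Dimethylamino stays apart from it, with a 63-fold higher number from compound 3 to compound 4 (1.80 log units; beyond the scatter), so among the groups shown it alone brings the number down. Taken from a limit, the remaining step is an at least 1.5-fold lower number from compound 2 to compound 4 (0.19 log units; that floor lies within the scatter). Compound 2 stands at a limit, which is not a number: the limit of > 10000000 nM in this assay, at which 1 of the 4 values shown sits.

As far as these compounds go, it remains open whether a smaller amine such as a primary amine, or a morpholine, would bring the number down as dimethylamino does. A carboxylic acid at this place also remains untested among the compounds shown.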